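The compounds below may be only part of what the source reports. "The series", "measured", "known", "first", "only" and "open" are said of these compounds alone.

Measured so far in a toxicity assay on Vero cells (Chlorocebus sabaeus) for cytotoxicity, read by MTT assay; on this read-out higher numbers stand for weaker inhibition and lower numbers for stronger inhibition:
compound 1 `COC(=O)NC(=O)c1ccsc1NC(=O)c1ccc(S(=O)(=O)N2CCCC2)cc1` gives 39.5 ug/mL;
compound 2 `COC(=O)NC(=O)c1ccsc1NC(=O)c1ccc(S(=O)(=O)N2CCCCCC2)cc1` gives 9.13 ug/mL;
compound 3 `COC(=O)NC(=O)c1ccsc1NC(=O)c1ccc(S(=O)(=O)N2CCC(OC)CC2)cc1` gives 18 ug/mL.

Within this small set compound 3 stands second highest of the three numbers. Its nearest neighbour is compound 2, and that gap is within the usual scatter (a 2.0-fold higher number from compound 2 to compound 3 (0.29 log units; within the scatter)), so the two cannot be told apart on these readings. Its gap from compound 1 is beyond the scatter (a 2.2-fold lower number from compound 1 to compound 3 (0.34 log units; beyond the scatter)), a modest drop.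

The next compound, compound 4 `COC(=O)NC(=O)c1ccsc1NC(=O)c1ccc(S(=O)(=O)NC2CCCCC2)cc1`, differs from compound 3 in one place: cyclohexylamino in place of 4-methoxypiperidin-1-yl on a sulfonyl sulfur.

Among the measured compounds shown here, two measured steps bear on a change at this position. Both replace the pyrrolidin-1-yl of compound 1 with a larger ring group on the sulfonyl sulfur, and both gave modestly lower numbers: a 4.3-fold lower number from compound 1 to compound 2 (0.64 log units; beyond the scatter) and a 2.2-fold lower number from compound 1 to compound 3 (0.34 log units; beyond the scatter). Between the two larger groups the step is within the scatter (a 2.0-fold higher number from compound 2 to compound 3 (0.29 log units; within the scatter)). For the measured compounds named here, no measured step removes a methoxy or brings in a group with a hydrogen-bond donor, so that part of the change has no precedent here.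

On this basis only a small step is expected, downward if anything: a 1.4-fold lower number from compound 3 to compound 4 (0.14 log units; within the scatter). Compound 4 is therefore estimated at 13 ug/mL, with a range from 5.5 ug/mL to 30 ug/mL.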

Compound 4, half-maximal inhibitory concentration: > 64 ug/mL
Compound 4 gave a limit, no number (the forecaster's own chance of this, stated with the estimate: 5%); at least 4.9-fold (0.69 log units) between middle value and limit.
By their numbers in this assay, from the lowest: compounds 2 and 3 (each within the scatter of the next); then compound 1. At a limit, above all of these: compound 4.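

In this assay compound 4 gives a limit and not a number: the limit of > 64 ug/mL in this assay, at which 1 of the 4 values shown sits. The earlier steps shown here showed only lower numbers when the pyrrolidin-1-yl of compound 1 gave way to a larger ring group, whereas cyclohexylamino on the same sulfonyl sulfur goes the other way, with an at least 3.5-fold higher number from compound 3 to compound 4 (0.55 log units; beyond the scatter) and an at least 7.0-fold higher number from compound 2 to compound 4 (0.84 log units; beyond the scatter). Both compound 3 and compound 4 carry a six-membered ring, so ring size alone does not set the read-out at this position, although the floor of an at least 1.6-fold higher number from compound 1 to compound 4 (0.20 log units; that floor lies within the scatter) means that the limit does not yet separate compound 4 from compound 1.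

The change from compound 3 to compound 4 removes the methoxy group and the ring oxygen's acceptor while bringing in a hydrogen-bond donor on the nitrogen, and these compounds cannot say which part matters. As far as these compounds go, a plain piperidin-1-yl group and a cyclohexyl(methyl)amino group on the sulfonyl sulfur would each isolate one part of that change, and the true value of compound 4 remains unknown beyond its limit.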